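The source may hold more compounds than are shown below. What is called first, only, known or untested is meant among the compounds shown, and "the series" means these compounds.

Measured compounds:
Compound 1 `O=C(Nc1cccc(-n2cc(-c3ccncc3)c(-c3ccc(Cl)c(O)c3)n2)c1)Nc1ccc(Cl)c(Cl)c1` gives 1050 nM in a functional assay on OVCAR-3 cells (Homo sapiens) for inhibition, read by sulforhodamine B assay, with a stated time of 48 h; on this read-out higher numbers stand for weaker inhibition and lower numbers for stronger inhibition.
Compound 2 `COc1cc(-c2nn(-c3cccc(NC(=O)c4ccc(Cl)c(C(F)(F)F)c4)c3)cc2-c2ccncc2)ccc1Cl` gives 2420 nM.
Compound 3 `COc1cc(-c2nn(-c3cccc(NC(=O)Nc4ccc(Cl)c(C(F)(F)F)c4)c3)cc2-c2ccncc2)ccc1Cl` gives 890 nM.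

Compound 3 has the lowest number of the three, though its gap to compound 1 is within the scatter; only compound 2 sits clearly higher, and a 2.7-fold lower number from compound 2 to compound 3 (0.43 log units; beyond the scatter) describes that step. Compound 4 `COc1cc(-c2nn(-c3cccc(NC(=O)Nc4ccc(Cl)c(Cl)c4)c3)cc2-c2ccncc2)ccc1Cl` differs from compound 3 by a single change: chloro in place of trifluoromethyl on an aromatic carbon. Going by the values given here, no measured step tests this exact change. Compound 1 carries the same 3,4-dichlorophenyl group on a core that also differs elsewhere, and its value is within the scatter of compound 3, which gives no ground for expecting a shift. Compound 4 is therefore estimated at 950 nM (range 400 nM to 2300 nM), meaning an expected step of a 1.1-fold higher number from compound 3 to compound 4 (0.03 log units; within the scatter), none beyond the scatter.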

Compound 4, half-maximal inhibitory concentration: 700 nM
Compound 4: the middle estimate sits 1.4-fold (0.13 log units) above what was measured, and the stated range covers the measured number.
By their numbers in this assay, from the lowest: compounds 4, 3 and 1 (each within the scatter of the next); then compound 2.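

On this aromatic carbon of the ring, chloro stands in for trifluoromethyl without a change that can be told from the scatter in this assay (a 1.3-fold lower number from compound 3 to compound 4 (0.10 log units; within the scatter)). Methyl in place of hydrogen on the oxygen also stays within the scatter (a 1.5-fold lower number from compound 1 to compound 4 (0.18 log units; within the scatter)), whereas the one clear step (a 3.5-fold lower number from compound 2 to compound 4 (0.54 log units; beyond the scatter)) brings in the amino link on the carbonyl carbon as well as the chloro. Nothing at hand explains these results. On these data alone, what a fluoro or a nitrile on this carbon would give remains open.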